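A branched chain on the amide nitrogen of compound 4

The source may report more compounds than this note shows. Statements on the series, on what has been measured and on what is new or still open speak of the compounds shown alone.

Of the compounds shown here, three sharing one core have been measured in an ADME assay (liver) for pharmacokinetics, with Liver microsome (Rattus norvegicus) as the target, using microsomes; on this read-out higher numbers stand for a longer-lived compound and lower numbers for a shorter-lived compound. Compound 1 `CCOc1cc(NC(=O)C2(NC(=O)c3ccc4c(C5CCCC5)c(-c5ncc(Cl)cn5)n(C)c4c3)CCC2)ccc1/C=C/C(=O)OCOP(=O)(O)O` gives 0.15 h. Compound 2 `CCOC(=O)/C=C/c1ccc(NC(=O)C2(NC(=O)c3ccc4c(C5CCCC5)c(-c5ncc(Cl)cn5)n(C)c4c3)CCC2)cc1OCC` gives 3.07 h, and compound 3 `CCCN(C)C(=O)COC(=O)/C=C/c1ccc(NC(=O)C2(NC(=O)c3ccc4c(C5CCCC5)c(-c5ncc(Cl)cn5)n(C)c4c3)CCC2)cc1OCC` gives 0.317 h. Compound 3 holds the second highest of the three numbers: its nearest neighbour is compound 1, reached by a 2.1-fold higher number from compound 1 to compound 3 (0.32 log units; beyond the scatter), and its furthest is compound 2, reached by a 9.7-fold lower number from compound 2 to compound 3 (0.99 log units; beyond the scatter). Compound 4 `CCOc1cc(NC(=O)C2(NC(=O)c3ccc4c(C5CCCC5)c(-c5ncc(Cl)cn5)n(C)c4c3)CCC2)ccc1/C=C/C(=O)OCC(=O)N(C)C(C)C` differs from compound 3 by isopropyl in place of propyl on an amide-type nitrogen. Both measured steps that reach compound 3 change the group on the saturated chain carbon bound to an oxygen next to a carbonyl group, and both are beyond the scatter, but none of them alters what sits on the amide-type nitrogen itself. The two chains entering and leaving compound 4 are counted the same, so no step beyond the scatter is expected in this assay for compound 4, in either direction; the estimate is a 1.1-fold higher number from compound 3 to compound 4 (0.04 log units; within the scatter). Compound 4 is therefore expected to give about 0.35 h, between 0.15 h and 0.8 h.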

Compound 4, half-life: 0.267 h
For compound 4 the middle estimate is 1.3-fold (0.12 log units) above the measured one; low and high end bracket the measured number.
By their numbers in this assay, from the lowest: compounds 1, 4 and 3 (each within the scatter of the next, the first and the last beyond it); then compound 2.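

In this assay, going by these compounds alone, the amide-type nitrogen is changed for the first time, and branching its chain gives a 1.2-fold lower number from compound 3 to compound 4 (0.07 log units; within the scatter), so propyl and isopropyl cannot be told apart at this position. The large fall on replacing methyl persists with the branched chain, with an 11-fold lower number from compound 2 to compound 4 (1.06 log units; beyond the scatter), which shows that the fall seen with the methyl(propyl)carbamoyl group of compound 3 is not tied to an unbranched chain. The phosphate-bearing compound 1 is no longer clearly separated, with a 1.8-fold higher number from compound 1 to compound 4 (0.25 log units; within the scatter), although its step to compound 3 lay just beyond the scatter.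

From the compounds shown here alone, whether a cyclopropyl ring, a longer chain such as butyl, or a free amine on this chain would shift the half-life stays open. No measured evidence bears on why these steps take the size they do.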